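The compounds below may be only part of what the source reports. "The series", "measured", "known", "first", "only" and "open" are said of these compounds alone.

Series notes. The three measured compounds share one core and differ only in the group carried on a saturated chain carbon bound to an aromatic carbon. Compound 1 `COc1cccc(Cc2cnc(CCc3ccc(-c4ccccc4C(=O)O)cc3)[nH]2)c1` carries 3-methoxyphenyl there, and in an in vitro functional assay on cells for agonist activity at Bombesin receptor subtype-3 (Mus musculus), read by luminescence and calcium flux (a lower number here means that less compound is needed, a higher number that more compound is needed for the effect), compound 1 gives 79 nM. Compound 2 `O=C(O)c1ccccc1-c1ccc(CCc2ncc(Cc3ccc(F)cc3)[nH]2)cc1` carries 4-fluorophenyl, and in this assay compound 2 gives 50 nM. Compound 3 `O=C(O)c1ccccc1-c1ccc(CCc2ncc(CC3CC3)[nH]2)cc1` carries cyclopropyl, and in this assay compound 3 gives 72 nM. Compound 3 stands second highest of the three numbers; its nearest neighbour is compound 1 and its furthest is compound 2, and both gaps lie within the scatter, so no order among the three can be read.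

The next compound, compound 4 `CCC(C)(CC)Cc1cnc(CCc2ccc(-c3ccccc3C(=O)O)cc2)[nH]1`, is made from compound 3 by 1-ethyl-1-methylpropyl in place of cyclopropyl on a saturated chain carbon bound to an aromatic carbon. The steps already measured at this position are a 1.1-fold lower number from compound 1 to compound 3 (0.04 log units; within the scatter) and a 1.4-fold higher number from compound 2 to compound 3 (0.16 log units; within the scatter), and between the two aryl members a 1.6-fold lower number from compound 1 to compound 2 (0.20 log units; within the scatter); all three lie within the scatter. The exchanges so far ran from 3-methoxyphenyl and 4-fluorophenyl to cyclopropyl; the branched open chain is a new kind of group, but nothing in the data shows this position moving the number beyond the scatter. The expected step is therefore a 1.0-fold lower number from compound 3 to compound 4 (0.01 log units; within the scatter), none beyond the scatter. Compound 4 is estimated at 70 nM in this assay, with a range of 25 nM to 200 nM.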

Compound 4, half-maximal effective concentration: 30 nM
For compound 4 the middle estimate is 2.3-fold (0.37 log units) above the measured one, within the range that was stated.
By their numbers in this assay, from the lowest: compounds 4, 2, 3 and 1 (each within the scatter of the next, the first and the last beyond it).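

At this position the number does move beyond the scatter: in this assay there is a 2.4-fold lower number from compound 3 to compound 4 (0.38 log units; beyond the scatter), and also a 2.6-fold lower number from compound 1 to compound 4 (0.42 log units; beyond the scatter), both modest, while a 1.7-fold lower number from compound 2 to compound 4 (0.22 log units; within the scatter) stays within the scatter, so compound 4 cannot be ordered against compound 2. An aryl or cyclic group is therefore not required on the saturated chain carbon bound to an aromatic carbon, since the open-chain 1-ethyl-1-methylpropyl of compound 4, with 6 heavy atoms and no ring, stands with compound 2 and clear of compound 3 and compound 1. No measurement in hand accounts for the step, and the change from cyclopropyl to 1-ethyl-1-methylpropyl alters ring and heavy-atom count together, so the two cannot be separated.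

Still open, on these data alone, is whether the branching, the open chain or the added carbon carries the step, which cyclohexyl or an unbranched pentyl chain at the same position would help to divide. Also open, as far as these compounds go, is how this position responds to a group bearing an amine or a hydroxyl, since both groups in this step have no hydrogen-bond donors or acceptors.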